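The compounds below may be only part of what the source reports. "The series", "measured", "known", "first", "only" and "open" are said of these compounds alone.

Going by the values given here, compound 3 `Cc1cccc(S(=O)(=O)NCc2ccc(CNC(=O)c3ccccc3C)cc2)c1` gives 1000 nM in an assay on MDA-MB-231 cells for displacement of a labelled ligand from C-X-C chemokine receptor type 4 (Homo sapiens), read by fluorescence and microscopy, with stated times of 10 min and 30 min (a lower number here means that less compound is needed, a higher number that more compound is needed for the effect), the highest of the three numbers measured so far. Its nearest neighbour is compound 1 `O=C(NCc1ccc(CNS(=O)(=O)c2ccccc2Cl)cc1)c1cccnc1`, which gives 100 nM in this assay, and the furthest is compound 2 `Cc1ccccc1C(=O)NCc1ccc(CNS(=O)(=O)c2ccc(F)cc2)cc1`, which gives 10 nM. Compound 4 `Cc1ccccc1C(=O)NCc1ccc(CNS(=O)(=O)c2ccccc2Cl)cc1` has not yet been measured in this assay. It differs from compound 3 in one place: 2-chlorophenyl in place of 3-methylphenyl on a sulfonyl sulfur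

Among the compounds with values here, only one measured step touches the same position, namely the change on the sulfonyl sulfur that gave a 100-fold higher number from compound 2 to compound 3 (2.00 log units; beyond the scatter). That step shows the group on the sulfonyl sulfur can move the number by a large amount, and that 3-methylphenyl sits at the weak end of what has been seen. The 2-chlorophenyl group itself appears in compound 1, whose value of 100 nM in this assay is well below that of compound 3, though the two also differ in the amide part, so no single step can be read from them. Taken together, a sizeable fall is expected for compound 4, and the estimate is a 17-fold lower number from compound 3 to compound 4 (1.22 log units; beyond the scatter). Compound 4 is therefore expected to give about 60 nM in this assay, within a range from 10 nM to 500 nM.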

Compound 4, effective concentration (reported as EC, without a stated level of effect): 1000 nM
Beside the measured number, compound 4's estimate is 17-fold (1.22 log units) below it; the measured number lies above the stated range.
By their numbers in this assay, from the lowest: compound 2; then compound 1; then compounds 3 and 4 (each within the scatter of the next).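

With the 2-methylphenyl amide held fixed in this assay, 2-chlorophenyl in place of 3-methylphenyl on a sulfonyl sulfur gives no change at the digits printed from compound 3 to compound 4 (within the scatter) and so leaves these two groups indistinguishable in this assay. The large effect seen earlier at this position therefore does not separate all groups from one another: 2-chlorophenyl in place of 4-fluorophenyl gives a 100-fold higher number from compound 2 to compound 4 (2.00 log units; beyond the scatter) and matches the earlier result of a 100-fold higher number from compound 2 to compound 3 (2.00 log units; beyond the scatter) with 3-methylphenyl, leaving compound 2 alone at the low end among these three compounds with the same amide. The lower number of compound 1 also cannot be credited to 2-chlorophenyl alone, since 2-methylphenyl in place of pyridin-3-yl on a carbonyl carbon gives a 10-fold higher number from compound 1 to compound 4 (1.00 log units; beyond the scatter) with the sulfonyl group unchanged, so the amide part also moves the number.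

The compounds shown leave open whether 4-chlorophenyl or 4-methoxyphenyl on the sulfonyl sulfur would give a number like that of compound 2, and whether pyridin-3-yl on the carbonyl carbon would lower the number when 4-fluorophenyl is present. No measurement offered here accounts for any of these steps.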